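Adding a Methyl to a Succinimide Amide: No Change Expected

The source may hold more compounds than are shown below. What is called first, only, known or untested is meant among the compounds shown, and "the series" means these compounds.

Measured compounds:
- compound 1 `COc1cccc(N2CCN(C(=O)C(C)N3C(=O)CCC3=O)CC2)c1` — 0%
- compound 2 `CCC(C(=O)N1CCN(c2cccc(OC)c2)CC1)N1C(=O)CCC1=O` — 0%
- compound 3 `CC(C(=O)N1CCOCC1)N1C(=O)CCC1=O` — 0%

Of the compounds shown here, three have been tested in a functional assay on the whole organism (strain Swiss) with Mus musculus as the target, in the maximal electroshock model, with a stated time of 1 h, at a dose of 300 mg/kg by the intraperitoneal route; on this read-out higher numbers stand for a stronger effect at the one dose given and lower numbers for a weaker effect. In this assay compound 1 gives 0%. Compound 2 differs from compound 1 by one change, (methyl in place of hydrogen on a saturated chain carbon, two bonds along the chain from an amide-type nitrogen in a ring and a carbonyl carbon), and in this assay compound 2 gives 0%. The step that this change made is no change at the digits printed from compound 1 to compound 2 (within the scatter).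

Compound 3 carries a different core; the difference between the two cores is not broken down here. In this assay compound 3 gives 0%, which is level with compound 1 and compound 2 at the digits printed, within the scatter in both cases.

Compound 4 `CCC(C(=O)N1CCOCC1)N1C(=O)CCC1=O` has not yet been measured. For the measured compounds named here, it differs from compound 3 by methyl in place of hydrogen on a saturated chain carbon, two bonds along the chain from an amide-type nitrogen in a ring and a carbonyl carbon, which is the same change as the one from compound 1 to compound 2, made at the same place on the chain. Because that change gave no change at the digits printed from compound 1 to compound 2 (within the scatter), and because compound 3 itself sits at 0%, the step from compound 3 to compound 4 is expected to be no change at the digits printed from compound 3 to compound 4 (within the scatter). Going by the values given here, the estimate for compound 4 in this assay is therefore 0%, with an expected range from 0% to 10%, resting only on the single earlier instance of this change and on the shared inactivity of the three measured compounds.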

Compound 4, a percentage reported as activity, at one dose (the size of the read-out at that dose, not a potency): 0%
Estimate against measurement, compound 4: no gap at the digits printed; the range from low to high includes it.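

In this assay, methyl in place of hydrogen on the saturated chain carbon gives no change at the digits printed from compound 3 to compound 4 (within the scatter). Set beside the earlier case, the change reads the same on both cores: the same change on two cores in this assay, no change at the digits printed (within the scatter) from compound 1 to compound 2 and no change at the digits printed (within the scatter) from compound 3 to compound 4, 0 percentage points apart, within the scatter of two such steps This agreement is narrow, however: compound 4 gives 0%, level with the other three compounds, so both steps start and end at this same value, and they show nothing about how the change would act on a core that has a measurable effect in this assay.

Still open, from the compounds shown here alone, is whether a longer chain on this carbon, or an amine or a carboxylic acid in place of the methyl, would lift the read-out from this level. Also open, going by these compounds, is how these four compounds would behave at any other dose or time, as each has been read here at only one dose and one time.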